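The source may report more compounds than this note shows. Statements on the series, on what has been measured and on what is new or still open speak of the compounds shown alone.

Of the compounds shown here, three sharing a closely related scaffold have been measured in an ADME assay on HeLa cells (Homo sapiens) for cytotoxicity, read by MTT assay, with a stated time of 72 h; a higher number here means that more compound is tolerated, a lower number that less compound is tolerated. Compound 1 `Oc1ccccc1/C=N/c1sc2c(c1-c1nc3ccccc3s1)CCC2` gives 168 ug/mL in this assay. Compound 2 `C(=C/c1ccccc1)\C=N\c1sc2c(c1-c1nc3ccccc3s1)CCC2` gives 100 ug/mL in this assay. Compound 3 `C(=C/c1ccccc1)\C=N\c1sc2c(c1-c1nc3ccccc3s1)CCCC2` gives 389 ug/mL in this assay, the highest of the three numbers; its distance from compound 1 and from compound 2 is beyond the scatter in each case.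

Compound 3 and compound 2 differ in their cores, and the difference between the two cores is not broken down here.

One structural change appears twice among these compounds. Between compound 2 and compound 1 it is 2-hydroxyphenyl in place of 2-phenylethenyl on a carbon with a double bond to nitrogen and it produced a 1.7-fold higher number from compound 2 to compound 1 (0.23 log units; within the scatter), a step that stays within the scatter. The same change, (2-hydroxyphenyl in place of 2-phenylethenyl on a carbon with a double bond to nitrogen), turns compound 3 into the unmeasured compound 4 `Oc1ccccc1/C=N/c1sc2c(c1-c1nc3ccccc3s1)CCCC2` in this assay; the two changes sit at the same place and are the same change.

Because the earlier step was a 1.7-fold higher number from compound 2 to compound 1 (0.23 log units; within the scatter) and stayed within the scatter, the step from compound 3 to compound 4 is expected to be of similar size, roughly a 1.4-fold higher number from compound 3 to compound 4 (0.15 log units; within the scatter). On that basis compound 4 is estimated to give about 550 ug/mL in this assay, most likely between 250 ug/mL and 1100 ug/mL.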

Compound 4, half-maximal cytotoxic concentration: 122 ug/mL
Compound 4: the middle estimate sits 4.5-fold (0.65 log units) above what was measured; the whole stated range lies above it.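

In this assay, putting 2-hydroxyphenyl in place of 2-phenylethenyl on a carbon with a double bond to nitrogen gave a 3.2-fold lower number from compound 3 to compound 4 (0.50 log units; beyond the scatter), and this step clearly differs from the one seen earlier on the other core: the same change on two cores in this assay, a 1.7-fold higher number (0.23 log units; within the scatter) from compound 2 to compound 1 and a 3.2-fold lower number (0.50 log units; beyond the scatter) from compound 3 to compound 4, 5.4-fold (0.73 log units) apart, beyond the scatter of two such steps
So in this series the change did not carry over from one core to the other with its size intact: on the core of compound 1 it stays within the scatter, while on the core of compound 4 it lowers the number beyond the scatter, which means that a step read on one of these cores is a poor guide to the same step on the other. For the compounds shown here, this does not show which feature of the two cores makes the steps differ, and with only two pairs it gives no general rule for how this change behaves on other cores.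

The compounds shown leave open how a third core would respond to the same change, and whether it would resemble either of these two. They also leave open what other groups at this place would do on both cores, such as 2-aminophenyl, a phenyl ring carrying a carboxylic acid, or a longer chain than 2-phenylethenyl.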